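From Methyl to Ethoxycarbonyl on an Active Amide

This account rests on a few compounds, and the source may have more. Where it says the series, first, only, none or still open, it means among the compounds named here.

Of the compounds shown here, three sharing one core have been measured in a functional assay on MDA-MB-231 cells (Homo sapiens) for antiproliferative activity, read by MTT assay, with a stated time of 72 h; a higher number here means a weaker inhibitor, a lower number a stronger inhibitor. Compound 1 `O=C(CCc1cccc2c1B(O)OC2)NCc1ccccc1` gives > 100000 nM, which is a limit of the assay. Compound 2 `O=C(CCc1cccc2c1B(O)OC2)Nc1nccs1` gives > 100000 nM, which is also a limit. Among the measured compounds shown here, compound 3 `Cc1ccc(NC(=O)CCc2cccc3c2B(O)OC3)cc1` gives 1100 nM, the only actual number among the three.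

Compound 4 `CCOC(=O)c1ccc(NC(=O)CCc2cccc3c2B(O)OC3)cc1` carries ethoxycarbonyl in place of the methyl of compound 3, on an aromatic carbon, para to a large group: ethoxycarbonyl in place of methyl on an aromatic carbon. For the measured compounds named here, two measured steps bear on this change, and both alter the group on the amide-type nitrogen. They are an at least 90-fold lower number from compound 1 to compound 3 (1.95 log units; beyond the scatter) and an at least 90-fold lower number from compound 2 to compound 3 (1.95 log units; beyond the scatter), both large. Compound 4 keeps the six-membered aromatic ring of carbon only on that nitrogen, which is the feature of the 4-methylphenyl group that entered in those steps. Going by the values given here, no measured step varies the methyl itself, so only a modest change is expected. In this assay, the expected change is a 2.3-fold higher number from compound 3 to compound 4 (0.36 log units; beyond the scatter). Compound 4 is estimated at 2500 nM, with an expected range of 400 nM to 15000 nM.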

Compound 4, half-maximal inhibitory concentration: > 100000 nM
Compound 4: no number, only a limit; the forecaster's own chance of this, stated with the estimate: 15%; middle value at least 40-fold (1.60 log units) from the limit.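

Until this point only the group on the amide-type nitrogen had changed, and this result shows that the aromatic carbon para to a large group also matters: in this assay, ethoxycarbonyl in place of methyl gives an at least 90-fold higher number from compound 3 to compound 4 (1.95 log units; beyond the scatter). Keeping the six-membered aromatic ring on that nitrogen therefore does not by itself preserve a measurable number. For compound 4, > 100000 nM is a limit of the assay and not a number, so the step has no upper bound, and compound 3 remains the only compound here with an actual value: the limit of > 100000 nM in this assay, at which 3 of the 4 values shown sit.

The compounds shown do not separate the ester from other replacements of the methyl at this carbon. A carboxylic acid, a primary amide, an ethyl chain or a chlorine at the same place would bear on that question.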